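Amide substituent and paw edema inhibition in a dimethoxy series

This account rests on a few compounds, and the source may have more. Where it says the series, first, only, none or still open, it means among the compounds named here.

Measured compounds:
compound 1 `CCNC(=O)CC1CCc2cc(OC)c(OC)cc21` — 15.6%
compound 2 `COc1cc2c(cc1OC)C(CC(=O)NC1CCCCC1)CC2` — 50%

In a functional assay on the whole organism (strain Wistar) for inhibition, with Rattus norvegicus as the target, read by paw edema, with stated times of 60 min and 1 h, at a dose of 100 mg/kg by the oral route (on this read-out higher numbers stand for more inhibition at the one dose given (going by the name of the read-out) and lower numbers for less inhibition), compound 1 gives 15.6%, while compound 2 gives 50%. Among the compounds with values here, compound 2 therefore holds the higher of the two numbers known so far, the change being a number 34.4 percentage points higher from compound 1 to compound 2 (beyond the scatter). The unmeasured compound 3 `COc1cc2c(cc1OC)C(CC(=O)NCCO)CC2` differs from compound 2 in one place: 2-hydroxyethyl in place of cyclohexyl on an amide-type nitrogen. Within the data shown here, the only measured step that bears on this is the one from compound 1 to compound 2, in which a cyclohexyl replaced an ethyl on the same amide-type nitrogen and the read-out rose well beyond the scatter. Going back from cyclohexyl to the short 2-hydroxyethyl chain resembles the reverse of that step, so a drop beyond the scatter is expected, estimated as a number 30 percentage points lower from compound 2 to compound 3 (beyond the scatter). Compound 3 is accordingly expected to give about 20%, within a range from 5% to 40%.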

Compound 3, a percentage reported as inhibition, in the whole organism at one dose (the size of the read-out at that dose, not a potency): 0%
For compound 3 the middle estimate is 20 percentage points above the measured one; the whole stated range lies above it.
By their numbers in this assay, from the lowest: compound 3; then compound 1; then compound 2.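

In this assay, the amide-type nitrogen now shows its substituent can move the read-out down as well as up: replacing cyclohexyl with 2-hydroxyethyl gives a number 50 percentage points lower from compound 2 to compound 3 (beyond the scatter). The more closely matched comparison isolates the hydroxy group, since hydroxy in place of hydrogen on a saturated chain carbon, two bonds along the chain from the amide-type nitrogen, gives a number 15.6 percentage points lower from compound 1 to compound 3 (beyond the scatter), so the ethyl chain's weak inhibition is lost further with this single change. No measurement available here accounts for either decrease.

The compounds shown leave open whether this loss is specific to the hydroxy group or would also occur with a methoxy group or an amine in its place. They also do not show whether a longer chain, a cyclopentyl ring or a phenyl ring on the same nitrogen would match or exceed cyclohexyl.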